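Adding methoxy to compound 3: a cytotoxicity estimate

The compounds below may be only part of what the source reports. "The series", "measured", "known", "first", "only" and "open" are said of these compounds alone.

Measured in an ADME assay on THP-1 cells (Homo sapiens) for cytotoxicity, read by flow cytometry and propidium iodide staining, with a stated time of 72 h; a higher number here means a weaker inhibitor, a lower number a stronger inhibitor:
- Compound 1 `COc1cccc(-c2cc(=O)c3cc(N)ccc3o2)c1`: > 125000 nM, a limit
- Compound 2 `Nc1ccc2oc(-c3cccc(F)c3)cc(=O)c2c1`: > 125000 nM, a limit
- Compound 3 `Nc1ccc2oc(-c3cccc(C(F)(F)F)c3)cc(=O)c2c1`: 34000 nM

Going by the values given here, compound 3, at 34000 nM, holds the only actual number in this short series. Compounds 1 and 2 both stand at the limit of > 125000 nM in this assay, at which 2 of the 3 values shown sit.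

Compound 4 `COc1c(-c2cccc(C(F)(F)F)c2)oc2ccc(N)cc2c1=O` carries methoxy in place of hydrogen on an aromatic carbon of the six-membered aromatic ring with 1 oxygen: methoxy in place of hydrogen on an aromatic carbon.

Three measured steps exist, and each changes the group that compound 3 carries as trifluoromethyl. They show an at least 3.6-fold lower number from compound 1 to compound 3 (0.56 log units; beyond the scatter) and an at least 3.6-fold lower number from compound 2 to compound 3 (0.56 log units; beyond the scatter), and there is also a step that the two limits leave unreadable from compound 1 to compound 2. None of them touches the carbon where the new methoxy enters, so they give only a loose guide. Compound 1 does carry a methoxy, but on a different carbon, and its limit cannot be transferred to this new place.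

Among the compounds with values here, with no measured step at this place, no step beyond the scatter is the best expectation in this assay, with some lean towards a higher number. The expected change is a 1.3-fold higher number from compound 3 to compound 4 (0.12 log units; within the scatter). For compound 4 the estimated value is 45000 nM, with an expected range of 16000 nM to 125000 nM.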

Compound 4, half-maximal inhibitory concentration: 33000 nM
The estimate for compound 4 lay 1.4-fold (0.13 log units) above the measured number, and the stated range covers the measured number.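

Going by these compounds alone, this step gives the first reading at this carbon of the six-membered aromatic ring with 1 oxygen, two atoms from the ring oxygen. Within the data shown here, all the earlier steps altered only the group that compound 3 carries as trifluoromethyl. In this assay, methoxy in place of hydrogen here gives a 1.0-fold lower number from compound 3 to compound 4 (0.01 log units; within the scatter), so for this pair the two compounds cannot be told apart, even though methoxy sits ortho to a large group. None of the information available here speaks to why this swap leaves the two compounds indistinguishable.

This single pair cannot show whether methoxy at this carbon would behave the same way in a compound carrying fluoro or methoxy on the other aromatic ring in place of trifluoromethyl, as compound 2 and compound 1 do. It also leaves open how this carbon would respond to other groups, such as a hydroxyl, an amine, a carboxylic acid or a longer chain like ethoxy, so the reading so far holds for methoxy alone.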